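Methyl for methoxy on a potent pair

The source may report more compounds than this note shows. Statements on the series, on what has been measured and on what is new or still open speak of the compounds shown alone.

Compound 1 `Cc1ccc(-n2nc(-c3ccc4ccccc4c3)nc2N2C(=O)COC23C=CC(=O)C=C3)cc1`: 30 nM
Compound 2 `COc1ccc(-n2nc(-c3ccc4ccccc4c3)nc2N2C(=O)C(C)OC23C=CC(=O)C=C3)cc1`: 50 nM

In a functional assay on MDA-MB-231 cells (Homo sapiens) for antiproliferative activity, with a stated time of 5 days (a higher number here means a weaker inhibitor, a lower number a stronger inhibitor), compound 2 gives 50 nM. For the measured compounds named here, its only neighbour on the numbers is compound 1 at 30 nM, and the gap between these two values lies within the usual scatter of repeated measurements. Neither can be called the stronger inhibitor.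

Compound 3 `Cc1ccc(-n2nc(-c3ccc4ccccc4c3)nc2N2C(=O)C(C)OC23C=CC(=O)C=C3)cc1` has not yet been measured. It keeps everything in compound 2 except one group: methyl in place of methoxy on an aromatic carbon, so 4-methoxyphenyl becomes 4-methylphenyl. Going by the values given here, no measured pair shows this change on its own, so any forecast is indirect. The best guide is compound 1, which also carries 4-methylphenyl and gives 30 nM. That value sits within the scatter of the 4-methoxyphenyl compound 2, so a large shift seems unlikely. The expected change a 1.3-fold lower number from compound 2 to compound 3 (0.10 log units; within the scatter) is small and is estimated to stay within the scatter. The estimated value for compound 3 is 40 nM, with an expected range of 18 nM to 90 nM.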

Compound 3, half-maximal inhibitory concentration: 100 nM
The estimate for compound 3 lay 2.5-fold (0.40 log units) below the measured number, and the stated range ends below it.
By their numbers in this assay, from the lowest: compounds 1, 2 and 3 (each within the scatter of the next, the first and the last beyond it).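

Read directly in this assay, the swap from 4-methoxyphenyl to 4-methylphenyl gives a 2.0-fold higher number from compound 2 to compound 3 (0.30 log units; within the scatter) and so, with the rest of the molecule held constant, this aromatic carbon carries either group without a difference that can be told from assay noise. For the compounds shown here, the clearer signal comes from a different place: with 4-methylphenyl kept fixed, methyl in place of hydrogen on the saturated ring carbon gives a 3.3-fold higher number from compound 1 to compound 3 (0.52 log units; beyond the scatter), a modest step but the only single change here that lies beyond the scatter. No measurement among these compounds offers an explanation for either step.

The compounds shown leave open whether the methyl on the saturated ring carbon would have a similar effect in a compound carrying 4-methoxyphenyl, since only the 4-methylphenyl pair reads that change on its own. They also leave open how far the tolerance at the aromatic carbon extends, for example to an amine, a carboxylic acid or a longer chain such as butyl, and whether an ethyl group on the saturated ring carbon would go further than methyl.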